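This account rests on a few compounds, and the source may have more. Where it says the series, first, only, none or still open, it means among the compounds named here.

In a functional assay on MCF7 cells (Homo sapiens) for inhibition, read by MTT assay, with a stated time of 48 h, tested at 10 uM (on this read-out higher numbers stand for more inhibition of growth at the one concentration tested and lower numbers for less inhibition of growth), compound 3 `CN1CC[C@H](c2c(O)cc(O)c3c(=O)cc(/C=C/c4ccccc4)oc23)[C@H](O)C1` gives 8% as its reading. That lies within the scatter of compound 1 `Cc1oc2c([C@H]3CCN(C)C[C@H]3O)c(O)cc(O)c2c(=O)c1C(O)c1ccc(F)c(Br)c1` at 14% and well short of compound 2 `Cc1oc2c([C@H]3CCN(C)C[C@H]3O)c(O)cc(O)c2c(=O)c1C(O)c1c(F)cccc1Cl` at 41% on the same scale. Compound 4 `CN1CC[C@H](c2c(O)cc(O)c3c(=O)cc(/C=C/c4cccc(F)c4)oc23)[C@H](O)C1` carries one change from compound 3 (fluoro in place of hydrogen on an aromatic carbon), turning phenyl into 3-fluorophenyl. Going by the values given here, only one measured step offers any guidance, a number 27 percentage points higher from compound 1 to compound 2 (beyond the scatter) on swapping one substituted phenyl for another. That step sits on a different side chain, however, and gives no direction for a single added fluoro. Therefore no step beyond the scatter is expected, with a number 4 percentage points higher from compound 3 to compound 4 (within the scatter) as the estimated change. The expected value for compound 4 is 12% with a likely range from 2% to 30% as the estimate.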

Compound 4, percent growth inhibition at one concentration: 83%
Compound 4: the middle estimate sits 71 percentage points below what was measured, and the stated range ends below it.
By their numbers in this assay, from the lowest: compounds 3 and 1 (each within the scatter of the next); then compound 2; then compound 4.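

On the 2-phenylethenyl side chain, a single fluoro in place of hydrogen, meta to a large group, gives a number 75 percentage points higher from compound 3 to compound 4 (beyond the scatter) in this assay. The earlier compounds shown here showed only one whole substituted phenyl exchanged for another on a different side chain, whereas here one added heavy atom, with no ring, charge, hydrogen-bond donor or acceptor, is enough to change the reading sharply. Nothing measured here gives a reason for this rise. Going by these compounds, whether methoxy or an amine on that same aromatic carbon would raise the reading as well remains open. So does whether this gain is specific to fluoro.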